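The source may hold more compounds than are shown below. What is called first, only, known or untested is meant among the compounds shown, and "the series" means these compounds.

Measured in an assay for inhibition of Amine oxidase [flavin-containing] A (Homo sapiens) (on this read-out higher numbers stand for weaker inhibition and lower numbers for stronger inhibition), so far:
compound 1 `CN1CCN(CCCC(O)c2ccc(-c3ccc(N4C[C@H](Cn5ccnn5)OC4=O)cc3F)cn2)CC1` gives 41000 nM
compound 2 `CN1CCN(CCCC(=O)c2ccc(-c3ccc(N4C[C@H](Cn5ccnn5)OC4=O)cc3F)cn2)CC1` gives 10500 nM
compound 3 `O=C1O[C@@H](Cn2ccnn2)CN1c1ccc(-c2ccc(C(O)C3CNC3)nc2)c(F)c1` gives 58000 nM

Compound 2 holds the lowest number of the three, separated from the rest by a 3.9-fold lower number from compound 1 to compound 2 (0.59 log units; beyond the scatter) and a 5.5-fold higher number from compound 2 to compound 3 (0.74 log units; beyond the scatter). Compound 4 `O=C(c1ccc(-c2ccc(N3C[C@H](Cn4ccnn4)OC3=O)cc2F)cn1)C1CCNCC1` differs from compound 2 by piperidin-4-yl in place of 3-(4-methylpiperazin-1-yl)propyl on a carbonyl carbon. For the measured compounds named here, no measured step exchanges the amine beside the carbonyl on its own. The closest comparison is a 1.4-fold higher number from compound 1 to compound 3 (0.15 log units; within the scatter), an amine exchange on the hydroxy-bearing carbon that stayed within the scatter. The larger 5.5-fold higher number from compound 2 to compound 3 (0.74 log units; beyond the scatter) combines an amine exchange with the carbonyl-to-hydroxy change, which by itself accounts for a 3.9-fold lower number from compound 1 to compound 2 (0.59 log units; beyond the scatter). Hence no step beyond the scatter is expected in this assay; compound 4 is estimated at 12000 nM, range 4000 nM to 36000 nM, meaning an expected 1.1-fold higher number from compound 2 to compound 4 (0.06 log units; within the scatter).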

Compound 4, inhibition constant: > 44000 nM
Compound 4 gave a limit, no number; the forecaster's own chance of this, stated with the estimate: 10%; middle value at least 3.6-fold (0.56 log units) from the limit.
By their numbers in this assay, from the lowest: compound 2; then compounds 1 and 3 (each within the scatter of the next).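

On the carbonyl carbon, the amine exchange alone now registers in this assay: piperidin-4-yl in place of 3-(4-methylpiperazin-1-yl)propyl gives an at least 4.1-fold higher number from compound 2 to compound 4 (0.62 log units; beyond the scatter). Compound 4 reads > 44000 nM, which is a limit of the assay and not a number. The carbonyl alone therefore does not secure the low number of compound 2, while the comparison with the hydroxy compound gives only a floor, an at least 1.0-fold higher number from compound 1 to compound 4 (0.03 log units; that floor lies within the scatter), and the step between compound 3 and compound 4 cannot be read.

As far as these compounds go, how far compound 4 lies past its limit remains open. Also open, from the compounds shown here alone, is whether the chain or the ring carries the difference, which a 3-(piperidin-1-yl)propyl group on the carbonyl carbon would separate.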